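Expecting Little Change from a 3-Chlorobenzyl Swap

This account rests on a few compounds, and the source may have more. Where it says the series, first, only, none or still open, it means among the compounds named here.

In a functional assay, read by spectrophotometry, with a stated time of 30 min (a lower number here means a stronger inhibitor, a higher number a weaker inhibitor), compound 1 (`Cc1ccc(CN2CCC(CCNC(=O)/C=C/c3cc(C(C)(C)C)c(O)c(C(C)(C)C)c3)CC2)cc1`) gives 60400 nM and compound 2 (`CC(C)(C)c1cc(/C=C/C(=O)NCCC2CCN(Cc3cccc(F)c3)CC2)cc(C(C)(C)C)c1O`) gives 55200 nM while compound 3 (`CC(C)(C)c1cc(/C=C/C(=O)NCCC2CCN(Cc3ccc(F)cc3F)CC2)cc(C(C)(C)C)c1O`) gives 62400 nM and so stands within the scatter of both others. Compound 4 (`CC(C)(C)c1cc(/C=C/C(=O)NCCC2CCN(Cc3cccc(Cl)c3)CC2)cc(C(C)(C)C)c1O`) differs from compound 3 by a single change (3-chlorophenyl in place of 2,4-difluorophenyl on a saturated chain carbon bound to an amine nitrogen in a ring): 3-chlorophenyl in place of 2,4-difluorophenyl on a saturated chain carbon bound to an amine nitrogen in a ring. Three measured steps at that same place bear on it. Moving to 3-fluorophenyl gave a 1.1-fold lower number from compound 1 to compound 2 (0.04 log units; within the scatter) and moving to 2,4-difluorophenyl gave a 1.0-fold higher number from compound 1 to compound 3 (0.01 log units; within the scatter) while exchanging those two groups gave a 1.1-fold higher number from compound 2 to compound 3 (0.05 log units; within the scatter) (all within the scatter). Only these three compounds inform the expectation, and none of them carries a chlorine. The step expected in this assay is estimated as a 1.1-fold lower number from compound 3 to compound 4 (0.03 log units; within the scatter) and thus none beyond the scatter, with no direction favoured. For compound 4 the estimated value is 58000 nM (expected range 38000 nM to 88000 nM).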

Compound 4, half-maximal inhibitory concentration: 83100 nM
For compound 4 the middle estimate is 1.4-fold (0.16 log units) below the measured one, and the stated range covers the measured number.
By their numbers in this assay, from the lowest: compounds 2, 1, 3 and 4 (each within the scatter of the next).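

In this assay, within the data shown here, a chlorine now stands on the aromatic ring at this position for the first time, and the change stays within the scatter against all three earlier compounds: a 1.3-fold higher number from compound 3 to compound 4 (0.12 log units; within the scatter), a 1.4-fold higher number from compound 1 to compound 4 (0.14 log units; within the scatter), and, for the plain exchange of chloro for fluoro on an aromatic carbon, a 1.5-fold higher number from compound 2 to compound 4 (0.18 log units; within the scatter). The position on a saturated chain carbon bound to an amine nitrogen in a ring has thus taken a chlorine as well as fluorine and methyl substituents without any listed step passing beyond the scatter. No measurement is available that would explain these results.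

The compounds shown do not tell whether any group at this place can move the number beyond the scatter. A phenyl carrying a carboxylic acid or an amine, or a longer chain in place of the benzyl group, would test this.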